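This account rests on a few compounds, and the source may have more. Where it says the series, first, only, none or still open, it means among the compounds named here.

In a physicochemical assay for solubility (on this read-out higher numbers stand for higher solubility and lower numbers for lower solubility), compound 1 (`CS(=O)(=O)c1ccc(-n2nc(C(F)F)c(C#N)c2-c2cc(F)cc(F)c2)cc1`) gives "not determined" (no result reported), so there is no number to start from. Compound 3 (`CS(=O)(=O)c1ccc(-n2nc(C(F)(F)F)c(C#N)c2NC2CCCC2)nc1`) likewise gives "not determined" (no result reported). Only compound 2 (`CC1CCCN(c2c(C#N)c(C(F)(F)F)nn2-c2ccc(S(C)(=O)=O)cn2)C1`) has a number, at 100 ug/mL. Compound 4 (`CS(=O)(=O)c1ccc(-n2nc(C(F)F)c(C#N)c2NC2CCCC2)cc1`) still awaits measurement. The step to follow is cyclopentylamino in place of 3,5-difluorophenyl on an aromatic carbon, with cyclopentylamino in place of 3,5-difluorophenyl on an aromatic carbon. Among the compounds with values here, no measured step shows what such a swap does in this assay. A moderate rise is expected, though this remains a judgement that compound 1 cannot check. Within the data shown here, the only anchor is compound 2 at 100 ug/mL, and a result somewhat short of that is expected. Compound 4 is estimated at 30 ug/mL, with an expected range from 6 ug/mL to 100 ug/mL.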

Compound 4, solubility: 100 ug/mL
The estimate for compound 4 lay 3.3-fold (0.52 log units) below the measured number, within the range that was stated.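

Within the data shown here, compound 1 has no number in this assay, so the change to compound 4 gives no step that can be read. The compounds shown leave open what cyclopentylamino in place of 3,5-difluorophenyl does on this read-out. No other evidence bears on this result.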